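Swapping the Amide Aryl Group: Expecting a Stronger Inhibitor

A few compounds are considered here, and "the series" means these few. Any claim that something is new, unique, unknown or untested is made for them only; others in the source may bear on it.

Compound 1 `CCN1CCN(c2cc(C)c3cc(NC(=O)c4cccc(Cl)c4)ccc3n2)CC1` gives 3820 nM in a functional assay on MCF7 cells (Homo sapiens) for antiproliferative activity, read by MTT assay, with a stated time of 72 h; a lower number here means a stronger inhibitor, a higher number a weaker inhibitor.
Compound 2 `Cc1cc(NCCN2CCN(C)CC2)nc2ccc(NC(=O)c3ccc(Cl)c(Cl)c3)cc12` gives 1700 nM in this assay.
Compound 3 `CCN1CCN(c2cc(C)c3cc(NC(=O)c4ccc(OC)cc4)ccc3n2)CC1` gives 7690 nM in this assay.

Among these three, compound 3 shows the highest number, that is the weakest inhibition. Its nearest neighbour is compound 1, and the step of a 2.0-fold higher number from compound 1 to compound 3 (0.30 log units; within the scatter) lies within the scatter, so the two cannot be told apart. For the measured compounds named here, compound 2 stands clearly lower, beyond the scatter, but it differs from compound 3 in more than one place, so no single step can be drawn between them.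

Compound 4 `CCN1CCN(c2cc(C)c3cc(NC(=O)c4ccc(Cl)c(Cl)c4)ccc3n2)CC1` is the untested compound. It differs from compound 3 by 3,4-dichlorophenyl in place of 4-methoxyphenyl on a carbonyl carbon. Compound 1 already carries one chlorine on that aromatic ring, and its number is on the lower side of compound 3 without leaving the scatter. Compound 2 carries the same 3,4-dichlorophenyl group on a different core and gives the lowest number seen here. Taken together, these point to a lower number for compound 4, and the step of a 3.1-fold lower number from compound 3 to compound 4 (0.49 log units; beyond the scatter) is my expected change in this assay. I estimate compound 4 at 2500 nM, within a range from 1000 nM to 6500 nM.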

Compound 4, half-maximal inhibitory concentration: 1380 nM
For compound 4 the middle estimate is 1.8-fold (0.26 log units) above the measured one; the measured number falls inside the stated range.
By their numbers in this assay, from the lowest: compounds 4 and 2 (each within the scatter of the next); then compounds 1 and 3 (each within the scatter of the next).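

The aryl group on this carbonyl carbon does matter in this assay: the step of a 5.6-fold lower number from compound 3 to compound 4 (0.75 log units; beyond the scatter) shows that replacing 4-methoxyphenyl with 3,4-dichlorophenyl moves the number beyond the scatter, which the earlier step from 3-chlorophenyl to 4-methoxyphenyl could not show. A smaller change at the same ring also registers, since chloro in place of hydrogen on an aromatic carbon gives a 2.8-fold lower number from compound 1 to compound 4 (0.44 log units; beyond the scatter) and separates the 3,4-dichlorophenyl amide from the 3-chlorophenyl amide on the shared core. With 3,4-dichlorophenyl held fixed, the other site gives a different picture, as 4-ethylpiperazin-1-yl in place of (2-(4-methylpiperazin-1-yl)ethyl)amino gives a 1.2-fold lower number from compound 2 to compound 4 (0.09 log units; within the scatter) and so leaves the two compounds indistinguishable here.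

The compounds shown leave open how a 4-chlorophenyl or a 3,4-difluorophenyl group would compare on this carbonyl carbon, and so whether the gain is tied to chlorine or to this particular arrangement on the ring. Nothing presented here explains why these groups give different numbers.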